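Compound 3 and its hydroxycarbamoyl end

The compounds below may be only part of what the source reports. "The series", "measured", "known", "first", "only" and "open" are said of these compounds alone.

Values in a functional assay on HeLa cells (Homo sapiens) for inhibition, read by MTT assay, with a stated time of 72 h; a lower number here means a stronger inhibitor, a higher number a weaker inhibitor:
compound 1 `CNC(=O)CCCCCCCn1nc(-c2cnc3[nH]ccc3c2)c2c(N)ncnc21`: 29100 nM
compound 2 `Nc1nc2cc(-c3nn(CCCCCCCCCC(=O)NO)c4ncnc(N)c34)ccc2o1`: > 50000 nM (a limit)
compound 3 `Nc1nc2cc(-c3nn(CCCCC(=O)NO)c4ncnc(N)c34)ccc2o1`: 32200 nM

Among the measured compounds shown here, the value of compound 3, 32200 nM, lies within the scatter of that of compound 1, the only other number in this assay. The entry for compound 2 is only a limit. Compound 4 `CNC(=O)CCCCCCCn1nc(-c2ccc3oc(N)nc3c2)c2c(N)ncnc21` differs from compound 3 by 3-(methylcarbamoyl)propyl in place of hydroxycarbamoyl on a saturated chain carbon, four bonds along the chain from an aromatic nitrogen. For the measured compounds named here, the one measured step at this place, an at least 1.5-fold lower number from compound 2 to compound 3 (0.19 log units; that floor lies within the scatter), has a floor within the scatter, so no step beyond the scatter is expected in this assay. The expected change is a 1.0-fold higher number from compound 3 to compound 4 (0.01 log units; within the scatter), an estimate only. For compound 4 the estimated value is 33000 nM, with an expected range of 15000 nM to 60000 nM.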

Compound 4, half-maximal inhibitory concentration: 12900 nM
Beside the measured number, compound 4's estimate is 2.6-fold (0.41 log units) above it; the measured number lies below the stated range.
By their numbers in this assay, from the lowest: compound 4; then compounds 1 and 3 (each within the scatter of the next). At a limit, above all of these: compound 2.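

In this assay, 3-(methylcarbamoyl)propyl in place of hydroxycarbamoyl gives a step beyond the scatter, which the earlier step at this place did not: a 2.5-fold lower number from compound 3 to compound 4 (0.40 log units; beyond the scatter). The comparison with the longer hydroxamate-free partner's opposite, the limit-bound entry, gives an at least 3.8-fold lower number from compound 2 to compound 4 (0.58 log units; beyond the scatter), a floor resting on a limit: the limit of > 50000 nM in this assay, at which 1 of the 4 values shown sits.

With the methylcarbamoyl chain kept, exchanging the aromatic group on the shared core also moves the number: a 2.3-fold lower number from compound 1 to compound 4 (0.35 log units; beyond the scatter).

Chain length and end group change together in the step to compound 4, and the compounds shown do not separate the two. Going by these compounds, how a carboxylic acid or an amine at the chain end would read in this assay stays open.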